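Adding a Methoxy Group in an Inactive Series

The source may report more compounds than this note shows. Statements on the series, on what has been measured and on what is new or still open speak of the compounds shown alone.

Compound 1, `COc1ccc(N2CCN(CC(=O)N3CCN(c4nnc(-c5ccccc5)c(-c5ccccc5)n4)CC3)CC2)cc1`, in a functional assay on MCF7 cells (Homo sapiens) for cytotoxicity, read by MTT assay, with a stated time of 24 h (a higher number here means a weaker inhibitor, a lower number a stronger inhibitor), gives only a limit, > 910000 nM.
Compound 2, `COc1ccc(-c2nnc(N3CCN(C(=O)CN4CCN(c5ccccc5)CC4)CC3)nc2-c2ccc(OC)cc2)cc1`, in this assay gives only a limit, > 863000 nM.

Neither measured compound has an actual number. Within the data shown here, compound 2 sits at the limit described by the limit of > 863000 nM in this assay, at which 1 of the 2 values shown sits, and the only other value shown is itself a limit, (the limit of > 910000 nM in this assay, at which 1 of the 2 values shown sits). Among the measured compounds shown here, there is thus no measured step between the two compounds, only two ceilings, and nothing says which of the two is the stronger inhibitor of these cells.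

Compound 3, `COc1ccc(-c2nnc(N3CCN(C(=O)CN4CCN(c5ccccc5OC)CC4)CC3)nc2-c2ccc(OC)cc2)cc1`, is the next compound, and it differs from compound 2 in a single place: methoxy in place of hydrogen on an aromatic carbon. In words, a methoxy takes the place of hydrogen on an aromatic carbon of the outer phenyl ring.

For the measured compounds named here, since no measured step exists, the only guide is that compound 2 gave a limit. The expected step of a number no higher from compound 2 to compound 3 (the limit leaves the size open) is none beyond the scatter, in either direction. Compound 3 is therefore expected to give about 863000 nM, with a range from 200000 nM to 3000000 nM, most probably again reported as a limit.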

Compound 3, half-maximal inhibitory concentration: > 821000 nM
Compound 3: only a limit was reported (the forecaster's own chance of this, stated with the estimate: 85%); the middle value does not contradict the limit.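

Compound 3, like compound 2, gives only a limit in this assay, so no step can be read between compound 2 and compound 3. The compounds shown leave open how strongly any of the three acts on these cells, and whether the change from phenyl to 2-methoxyphenyl makes any difference.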